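Thioether in Place of the Hydroxy Side Chain

The source may hold more compounds than are shown below. What is called first, only, known or untested is meant among the compounds shown, and "the series" means these compounds.

For the measured compounds named here, compound 2 `CC(C)c1n[nH]c2c(NCc3ccc(-c4ccccn4)cc3)nc(SCC(C)(C)O)nc12` gives 507 nM in a functional assay on HT cells (Homo sapiens) for antiproliferative activity, read by fluorescence, with a stated time of 72 h (a lower number here means a stronger inhibitor of growth, a higher number a weaker inhibitor of growth), the highest of the two numbers so far; compound 1 `CC(C)c1n[nH]c2c(NCc3ccc(-c4ccccn4)cc3)nc(SCC(N)=O)nc12` gives 192 nM in this assay. Compound 3 `CSCCSc1nc(NCc2ccc(-c3ccccn3)cc2)c2[nH]nc(C(C)C)c2n1` carries (methylsulfanyl)methyl in place of 1-hydroxy-1-methylethyl on a saturated chain carbon bound to a sulfur. Going by the values given here, the one measured step, a 2.6-fold higher number from compound 1 to compound 2 (0.42 log units; beyond the scatter), sits on the same saturated chain carbon bound to a sulfur but exchanges different groups, so it guides the new change only loosely. A step of a 1.4-fold higher number from compound 2 to compound 3 (0.14 log units; within the scatter) is expected, toward a weaker inhibitor or none beyond the scatter. Compound 3 is estimated at 700 nM, within 250 nM to 2000 nM.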

Compound 3, concentration for 50% growth inhibition: 975 nM
Compound 3: the middle estimate sits 1.4-fold (0.14 log units) below what was measured; measured number inside the range.
By their numbers in this assay, from the lowest: compound 1; then compounds 2 and 3 (each within the scatter of the next).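

In this assay, 2-(methylsulfanyl)ethyl in place of 2-hydroxy-2-methylpropyl gives a 1.9-fold higher number from compound 2 to compound 3 (0.28 log units; within the scatter), so this change, which leaves 0 hydrogen-bond donors on the side chain, is not resolved from the scatter. Carbamoyl remains the distinct group at this position: replacing it with (methylsulfanyl)methyl gives a 5.1-fold higher number from compound 1 to compound 3 (0.71 log units; beyond the scatter), and compound 1 now has steps beyond the scatter to both other compounds. No measurement here accounts for these differences.

Open, on these data alone, is how an amine or a carboxylic acid on the saturated chain carbon bound to a sulfur would compare with carbamoyl. Also open, as far as these compounds go, is whether a longer chain ending in carbamoyl would hold the number of compound 1.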